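Dichlorobenzyl Replaces Methoxybenzyl on the Thioether Arm

A few compounds are considered here, and "the series" means these few. Any claim that something is new, unique, unknown or untested is made for them only; others in the source may bear on it.

Measured compounds, with their values in an ADME assay on HepG2 cells (Homo sapiens) for cytotoxicity, with a stated time of 48 h; a higher number here means a weaker inhibitor, a lower number a stronger inhibitor:
Compound 1, `CCn1c(SCc2ccccc2)nnc1-c1cc([N+](=O)[O-])cc([N+](=O)[O-])c1`, gives > 30000 nM.
Compound 2, `CCCCCCn1c(SCc2ccccc2)nnc1-c1cc([N+](=O)[O-])cc([N+](=O)[O-])c1`, gives > 30000 nM.
Compound 3, `COc1ccc(CSc2nnc(-c3cc([N+](=O)[O-])cc([N+](=O)[O-])c3)n2C)cc1`, gives > 30000 nM.

Each of these three values is a limit of this assay and not a number. Compound 3 therefore stands at the limit of > 30000 nM in this assay, at which 3 of the 3 values shown sit, and nothing in the numbers shown separates it from compound 1 or compound 2. For the measured compounds named here, the one step that can be built between measured compounds, a step that the two limits leave unreadable from compound 1 to compound 2, is left unreadable by the two limits, so no measured step gives a readable size.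

Compound 4, `Cn1c(SCc2ccc(Cl)c(Cl)c2)nnc1-c1cc([N+](=O)[O-])cc([N+](=O)[O-])c1`, differs from compound 3 by 3,4-dichlorophenyl in place of 4-methoxyphenyl on a saturated chain carbon bound to a sulfur. No measured step touches the benzyl group on the sulfur, so nothing shown bears directly on this change. Going by the values given here, since all three measured compounds sit at the limit of this assay and the only step between them is unreadable, no step beyond the scatter is expected from compound 3 to compound 4; the estimated step is a number no higher from compound 3 to compound 4 (the limit leaves the size open). For compound 4 in this assay the expected value is 30000 nM, with a range from 15000 nM to 60000 nM, most likely again reported only as a limit.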

Compound 4, half-maximal inhibitory concentration: > 30000 nM
Compound 4: a limit, no number; the forecaster's own chance of this, stated with the estimate: 80%; the middle value lies on the limit itself.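

Compound 3 and compound 4 are both reported only as limits, so no step can be read between them, and the values give no comparison: the limit of > 30000 nM in this assay, at which 4 of the 4 values shown sit.

The compounds shown leave open how the four differ in this assay, and whether any change to the benzyl group on the sulfur would yield a readable number.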